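Benzyl for Cyclohexyl on an Aromatic Nitrogen, Second Instance

The source may hold more compounds than are shown below. What is called first, only, known or untested is meant among the compounds shown, and "the series" means these compounds.

Measured compounds:
Compound 1, `c1ccc2c(-c3cn4ccnc4c(-c4ccc5ncn(C6CCCCC6)c5c4)n3)cccc2c1`: 14%
Compound 2, `c1ccc(Cn2cnc3ccc(-c4nc(-c5cccc6ccccc56)cn5ccnc45)cc32)cc1`: 6.74%
Compound 3, `c1cn2cc(-c3ccc4c(c3)ncn4C3CCCCC3)nc(-c3ccc4ncn(C5CCCCC5)c4c3)c2n1`: 16.3%

In a functional assay on A498 cells (Homo sapiens) for inhibition, read by sulforhodamine B assay, with a stated time of 48 h, tested at 10 uM (a lower number here means less inhibition, a higher number more inhibition at the concentration tested (going by the name of the read-out)), compound 1 gives 14%, and compound 2 gives 6.74%. The change between them is benzyl in place of cyclohexyl on an aromatic nitrogen, and the step it made was a number 7.3 percentage points lower from compound 1 to compound 2 (within the scatter). Compound 3 gives 16.3% in this assay; how its core differs from that of compound 1 is not broken down here. Compound 4, `c1ccc(Cn2cnc3ccc(-c4nc(-c5ccc6c(c5)ncn6C5CCCCC5)cn5ccnc45)cc32)cc1`, has not yet been measured. It differs from compound 3 by benzyl in place of cyclohexyl on an aromatic nitrogen, the same change as between compound 1 and compound 2, made at the same kind of place.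

Resting on compound 1 and compound 2, whose step was a number 7.3 percentage points lower from compound 1 to compound 2 (within the scatter), a similar step is expected for compound 4 in this assay, namely a number 7.3 percentage points lower from compound 3 to compound 4 (within the scatter). Compound 4 is therefore estimated at 9%, with a range from 0% to 20%.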

Compound 4, a percentage reported as inhibition, at one concentration (the size of the read-out at that concentration, not a potency): -71.8%
Compound 4: the middle estimate sits 80.8 percentage points above what was measured, and the stated range ends above it.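

In this assay, benzyl in place of cyclohexyl on an aromatic nitrogen gave a number 88.1 percentage points lower from compound 3 to compound 4 (beyond the scatter). The size of this step therefore did not carry from one core to the other: the same change on two cores in this assay, a number 7.3 percentage points lower (within the scatter) from compound 1 to compound 2 and a number 88.1 percentage points lower (beyond the scatter) from compound 3 to compound 4, 80.8 percentage points apart, beyond the scatter of two such steps This shows that, in these two pairs, the outcome of the change depends on the core it is made on; it does not show which difference between the cores is responsible, and two pairs set no rule for the series.

The compounds shown leave open how a butyl chain or a chain ending in an amine on that aromatic nitrogen would behave on either core. They also leave open what the negative reading of compound 4, -71.8%, stands for in the cells.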